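A few compounds are considered here, and "the series" means these few. Any claim that something is new, unique, unknown or untested is made for them only; others in the source may bear on it.

Compound 1 `O=C(N[C@@H](CCC(=O)N1CCN(c2cccc(NC3=NCCCN3)c2)CC1)C(=O)O)OCc1ccccc1` sets the reference: in a functional assay (muscle tissue) for inhibition, with Homo sapiens as the target (on this read-out lower numbers stand for stronger inhibition and higher numbers for weaker inhibition), compound 1 gives 1.1 nM. Compound 2 `Cc1cc(C)c(S(=O)(=O)N[C@@H](CCC(=O)N2CCN(c3cccc(NC4=NCCCN4)c3)CC2)C(=O)O)c(C)c1` reaches only a limit in this assay, > 10 nM, so its place is known only up to that limit (the limit of > 10 nM in this assay, at which 1 of the 2 values shown sits). Going by the values given here, the single measured step, an at least 9.0-fold higher number from compound 1 to compound 2 (0.95 log units; beyond the scatter), is the only guide. Compound 3 `O=C(NCc1ccccc1)N[C@@H](CCC(=O)N1CCN(c2cccc(NC3=NCCCN3)c2)CC1)C(=O)O` carries the change (benzylcarbamoyl in place of (2,4,6-trimethylphenyl)sulfonyl on an amine nitrogen), a benzylcarbamoyl closer to the benzyloxycarbonyl of compound 1 than to the sulfonyl of compound 2. With an expected step of an at least 4.0-fold lower number from compound 2 to compound 3 (0.60 log units; beyond the scatter), compound 3 should recover most of that ground. The estimate for compound 3 is 2.5 nM, within 0.8 nM to 9 nM.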

Compound 3, half-maximal inhibitory concentration: > 10 nM
Compound 3 gave a limit, no number; the forecaster's own chance of this, stated with the estimate: 10%; at least 4.0-fold (0.60 log units) between middle value and limit.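

Benzylamino in place of benzyloxy on a carbonyl carbon gives an at least 9.0-fold higher number from compound 1 to compound 3 (0.95 log units; beyond the scatter), so this amine nitrogen distinguishes even two closely matched carbonyl groups, not only benzyloxycarbonyl and (2,4,6-trimethylphenyl)sulfonyl. Compound 3 stands at a limit, > 10 nM, not a number. The step from compound 2 to compound 3 cannot be read, as both stop at the same limit: the limit of > 10 nM in this assay, at which 2 of the 3 values shown sit.

As far as these compounds go, how far compound 2 and compound 3 each lie past that limit stays open. Also open, from the compounds shown here alone, is whether acetyl or phenethyloxycarbonyl on this amine nitrogen would keep a value near that of compound 1.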